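Swapping Diethylamino for Piperidin-1-yl on Compound 3

This account rests on a few compounds, and the source may have more. Where it says the series, first, only, none or still open, it means among the compounds named here.

- compound 1 `O=c1cc(-c2ccccc2Cl)oc2cc(CN3CCCCC3)ccc12` gives 3640 nM
- compound 2 `CCN(CC)Cc1cccc2c(=O)cc(-c3ccc([N+](=O)[O-])cc3)oc12` gives 28800 nM
- compound 3 `CCN(CC)Cc1cc(Cl)cc2c(=O)cc(-c3ccc([N+](=O)[O-])cc3)oc12` gives 1190 nM

In a functional assay on HepG2 cells (Homo sapiens) for cytotoxicity, read by MTT assay, with a stated time of 48 h (a lower number here means a stronger inhibitor, a higher number a weaker inhibitor), compound 3 has the lowest of the three numbers at 1190 nM and its gaps to compound 1 and compound 2 both lie beyond the usual scatter. The next compound is compound 4 `O=c1cc(-c2ccc([N+](=O)[O-])cc2)oc2c(CN3CCCCC3)cc(Cl)cc12` and the change leading to it is piperidin-1-yl in place of diethylamino on a saturated chain carbon bound to an aromatic carbon with piperidin-1-yl in place of diethylamino on a saturated chain carbon bound to an aromatic carbon.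

Going by the values given here, the only measured step is a 24-fold lower number from compound 2 to compound 3 (1.38 log units; beyond the scatter) with chloro in place of hydrogen on an aromatic carbon. That step is large, but compound 3 and compound 4 both carry the chloro, so it does not speak to the amine. Among the compounds with values here, no measured pair makes this swap. Compound 1 carries piperidin-1-yl and gives 3640 nM but differs from compound 3 elsewhere too, so it cannot isolate the change. No shift beyond the scatter is therefore expected in this assay and no direction is favoured. The expected step is a 1.1-fold higher number from compound 3 to compound 4 (0.04 log units; within the scatter) and it is held loosely. The estimate for compound 4 is 1300 nM with an expected range of 450 nM to 3500 nM until the measurement arrives.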

Compound 4, half-maximal inhibitory concentration: 8910 nM
Estimate against measurement, compound 4: 6.9-fold (0.84 log units) below, outside the stated range (above it).
By their numbers in this assay, from the lowest: compound 3; then compound 1; then compound 4; then compound 2.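

In this assay, the amine on the saturated chain carbon bound to an aromatic carbon proves to matter: piperidin-1-yl in place of diethylamino gives a 7.5-fold higher number from compound 3 to compound 4 (0.87 log units; beyond the scatter), with nothing else in the structure changed. Going by these compounds alone, the earlier compounds could not show this, since their one readable step, a 24-fold lower number from compound 2 to compound 3 (1.38 log units; beyond the scatter), concerns the chloro on an aromatic carbon, and compound 1 differs from compound 3 in more than one place. The amine is therefore a second place in this series where a single change moves the number beyond the scatter, and nothing available here accounts for the direction or the size of this step.

The compounds shown leave open whether the higher number follows from closing the two ethyl groups into a ring or from the larger group as such, a question that pyrrolidin-1-yl, morpholin-4-yl or dimethylamino at the same place would help to settle. They also leave open whether the amine swap has a step of similar size without the chloro, or whether the chloro step holds with piperidin-1-yl in place.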